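Bromo in Place of Chloro: An Expected Small Step

A few compounds are considered here, and "the series" means these few. Any claim that something is new, unique, unknown or untested is made for them only; others in the source may bear on it.

Compound 1 `NC(=O)c1c(NC(=O)c2ccccc2Cl)sc2c1CCN(C(=S)Nc1ccccc1F)C2`: 4970 nM
Compound 2 `NC(=O)c1c(NC(=O)c2ccccc2Cl)sc2c1CCN(C(=S)Nc1ccccc1I)C2`: 4430 nM

Among the measured compounds shown here, in a functional assay on HL-60 cells (Homo sapiens) for antiproliferative activity, with a stated time of 24 h (on this read-out lower numbers stand for stronger inhibition and higher numbers for weaker inhibition), compound 1 gives the higher of the two numbers known so far, and its nearest neighbour is compound 2; the step from one to the other is a 1.1-fold lower number from compound 1 to compound 2 (0.05 log units; within the scatter). Compound 3 `NC(=O)c1c(NC(=O)c2ccccc2Br)sc2c1CCN(C(=S)Nc1ccccc1F)C2` differs from compound 1 by bromo in place of chloro on an aromatic carbon. For the measured compounds named here, no measured step touches this position; the only one available, a halogen swap elsewhere, was a 1.1-fold lower number from compound 1 to compound 2 (0.05 log units; within the scatter), and it hints that a halogen exchange leaves this read-out roughly unchanged. Compound 3 is therefore expected to give 4800 nM, between 2000 nM and 12000 nM, a step of a 1.0-fold lower number from compound 1 to compound 3 (0.02 log units; within the scatter) with no change beyond the scatter expected.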

Compound 3, half-maximal inhibitory concentration: > 50000 nM
Compound 3: a limit, no number; the forecaster's own chance of this, stated with the estimate: 5%; middle value at least 10-fold (1.01 log units) away from the limit.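

At this position the halogen matters: in this assay, bromo in place of chloro on the ring of the 2-chlorophenyl group gives an at least 10-fold higher number from compound 1 to compound 3 (1.00 log units; beyond the scatter). The earlier halogen swap elsewhere gave a 1.1-fold lower number from compound 1 to compound 2 (0.05 log units; within the scatter), so that swap did not carry over to this place. The value of compound 3 is a limit, not a number: the limit of > 50000 nM in this assay, at which 1 of the 3 values shown sits.

On these data alone, it remains open whether fluoro, a methyl group or an amine at this position would give a number close to that of compound 1 or one like that of compound 3.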